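From Cyclohexyl(methyl)amino to Cyclopentyl(ethyl)amino: an Expected Value

A few compounds are considered here, and "the series" means these few. Any claim that something is new, unique, unknown or untested is made for them only; others in the source may bear on it.

Two compounds have so far been measured in an assay on HeLa cells for inhibition of Indoleamine 2,3-dioxygenase 1 (Homo sapiens), with stated times of 1 h and 18 h; a higher number here means a weaker inhibitor, a lower number a stronger inhibitor:

compound 1 `Cc1ccc(NC(=O)Nc2cc(-c3ccccc3C(=O)O)ccc2NC2CCCCC2)cc1`: 504 nM
compound 2 `Cc1ccc(NC(=O)Nc2cc(-c3ccccc3C(=O)O)ccc2N(C)C2CCCCC2)cc1`: 14 nM

Compound 2 stands at the lowest of the two numbers. Among the measured compounds shown here, its only neighbour is compound 1, and the step of a 36-fold lower number from compound 1 to compound 2 (1.56 log units; beyond the scatter) separates them.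

Compound 3 `CCN(c1ccc(-c2ccccc2C(=O)O)cc1NC(=O)Nc1ccc(C)cc1)C1CCCC1` has not been measured. It differs from compound 2 by cyclopentyl(ethyl)amino in place of cyclohexyl(methyl)amino on an aromatic carbon. The two have the same atoms joined differently, so the change is a rearrangement of the substituents on that nitrogen rather than a gain or loss of atoms.

For the measured compounds named here, only one measured step exists, a 36-fold lower number from compound 1 to compound 2 (1.56 log units; beyond the scatter), and it concerns putting methyl in place of hydrogen on the nitrogen. It shows that what sits on this nitrogen can move the number a great deal. Going by the values given here, no measured pair, however, compares two different alkyl groups or two ring sizes on that nitrogen, so the direction of the present step is not indicated by the data. The expected step is therefore a 1.4-fold higher number from compound 2 to compound 3 (0.15 log units; within the scatter), with a wide range to reflect the lack of a guiding step. For compound 3 the estimate is 20 nM, between 6 nM and 70 nM.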

Compound 3, half-maximal inhibitory concentration: 23 nM
Estimate against measurement, compound 3: 1.2-fold (0.06 log units) below; measured number inside the range.
By their numbers in this assay, from the lowest: compounds 2 and 3 (each within the scatter of the next); then compound 1.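

In this assay, cyclopentyl(ethyl)amino in place of cyclohexyl(methyl)amino on this aromatic carbon gives a 1.6-fold higher number from compound 2 to compound 3 (0.22 log units; within the scatter) and so leaves compound 2 and compound 3 within the scatter of each other, even though the ring and the chain on the nitrogen both differ. The earlier compounds shown here showed only that adding methyl to the nitrogen of cyclohexylamino could move the number a great deal, whereas this pair shows that a five-membered ring with ethyl and a six-membered ring with methyl can give values that the assay does not separate. The second new comparison, a 22-fold lower number from compound 1 to compound 3 (1.34 log units; beyond the scatter) in the same assay, places compound 3 with compound 2 and well apart from compound 1, so among these three compounds both with a second carbon group on the nitrogen have the lower numbers, and none goes against this.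

Ring and chain change together here, so cyclopentyl(methyl)amino or cyclohexyl(ethyl)amino would be needed to tell whether their separate contributions are each small or happen to offset one another. No independent evidence bears on this result.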